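Aryl exchange in the sigma series: working notes

The source may report more compounds than this note shows. Statements on the series, on what has been measured and on what is new or still open speak of the compounds shown alone.

Compound 1 `CN(C)CCCCCCCCOc1ccc2oc(-c3ccccc3)cc(=O)c2c1` gives 143 nM in an assay on isolated protein (Cavia porcellus) with Sigma non-opioid intracellular receptor 1 (Homo sapiens) as the target, read by radioligand binding; on this read-out higher numbers stand for weaker inhibition and lower numbers for stronger inhibition.
Compound 2 `O=c1cc(-c2ccccc2)oc2ccc(OCCCCCCN3CCCCC3)cc12` gives 54 nM in this assay.
Compound 3 `O=c1cc(-c2ccccc2Cl)oc2ccc(OCCCCCCN3CCC(O)CC3)cc12` gives 29 nM in this assay.

Compound 3 carries the lowest of the three numbers, and its distance to compound 2 is within the scatter, so the two are not separated; its distance to compound 1 is beyond the scatter.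

Compound 4 `COc1cccc(-c2cc(=O)c3cc(OCCCCCCN4CCC(O)CC4)ccc3o2)c1` differs from compound 3 by 3-methoxyphenyl in place of 2-chlorophenyl on an aromatic carbon.

Going by the values given here, the only measured step in the set, a 2.6-fold lower number from compound 1 to compound 2 (0.42 log units; beyond the scatter), concerns the amine end of the chain and not the aryl group, so nothing measured bears directly on this change. Compound 2 and compound 3 differ in two places at once, so their gap cannot be assigned to the aryl group alone. Among the compounds with values here, with no matching precedent, no step beyond the scatter is expected, and compound 4 is expected to give 40 nM in this assay, with a range from 15 nM to 110 nM, which means an expected step of a 1.4-fold higher number from compound 3 to compound 4 (0.14 log units; within the scatter).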

Compound 4, half-maximal inhibitory concentration: 111 nM
The estimate for compound 4 lay 2.8-fold (0.44 log units) below the measured number; the whole stated range lies below it.
By their numbers in this assay, from the lowest: compounds 3 and 2 (each within the scatter of the next); then compounds 4 and 1 (each within the scatter of the next).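

Going by these compounds alone, the exchange of 2-chlorophenyl for 3-methoxyphenyl on the aromatic carbon next to the ring oxygen gives a 3.8-fold higher number from compound 3 to compound 4 (0.58 log units; beyond the scatter) as the first measured step at this position, so the number in this assay responds to the aryl group as well as to the amine end of the chain. The step alters both the substituent and its place on the phenyl ring, and these two changes cannot be told apart from this pair. Nothing available accounts for the size of this step.

Still open, from the compounds shown here alone, is whether 2-methoxyphenyl or 3-chlorophenyl on the same core and chain would fall nearer compound 3 or compound 4, which would separate the substituent from its place on the ring. Also open, going by these compounds, is how a nitrile or a trifluoromethyl group on that phenyl ring would read.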